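The compounds below may be only part of what the source reports. "The series", "measured", "known", "first", "only" and "open" are said of these compounds alone.

Series notes. Among the measured compounds shown here, compound 3 `Cc1ccc(OCC(=O)N2CCN(c3ccc(C(F)(F)F)cc3[C@@H](N)CC(C)C)CC2)cc1` gives 4400 nM in an assay on HEK293 cells for displacement of a labelled ligand from Melanocortin receptor 4 (Homo sapiens) (on this read-out lower numbers stand for stronger inhibition and higher numbers for weaker inhibition), the highest number of the three measured so far; compound 1 `Cc1ccc(CC(C)C(=O)N2CCN(c3ccc(C(F)(F)F)cc3[C@@H](N)CC(C)C)CC2)cc1C` gives 240 nM and compound 2 `CC(C)C[C@H](N)c1cc(C(F)(F)F)ccc1N1CCN(C(=O)COc2ccc3ccccc3c2)CC1` gives 2000 nM. Compound 4 `CC(C)C[C@H](N)c1cc(C(F)(F)F)ccc1N1CCN(C(=O)COc2cccc(Cl)c2)CC1` is the next member: 3-chlorophenyl in place of 4-methylphenyl on an oxygen on a saturated carbon. For the measured compounds named here, no measured step bears directly on a chlorine-for-methyl exchange on this ring; the only step touching this part of the molecule is a 2.2-fold higher number from compound 2 to compound 3 (0.34 log units; beyond the scatter), a modest change. The steps of an 8.3-fold higher number from compound 1 to compound 2 (0.92 log units; beyond the scatter) and an 18-fold higher number from compound 1 to compound 3 (1.26 log units; beyond the scatter) altered the whole chain on the carbonyl carbon and carry less weight here. For compound 4 a step of about a 1.5-fold lower number from compound 3 to compound 4 (0.17 log units; within the scatter) is expected, close to the scatter and toward a somewhat lower number. Compound 4 is therefore estimated at 3000 nM, range 1000 nM to 10000 nM in this assay.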

Compound 4, inhibition constant: 2600 nM
Compound 4: the middle estimate sits 1.2-fold (0.06 log units) above what was measured; measured number inside the range.
By their numbers in this assay, from the lowest: compound 1; then compounds 2, 4 and 3 (each within the scatter of the next, the first and the last beyond it).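

Within this assay, the steps of a 1.7-fold lower number from compound 3 to compound 4 (0.23 log units; within the scatter) and a 1.3-fold higher number from compound 2 to compound 4 (0.11 log units; within the scatter) both lie within the scatter, so 3-chlorophenyl on this oxygen cannot be told apart from either 4-methylphenyl or naphthalen-2-yl. The step of an 11-fold higher number from compound 1 to compound 4 (1.03 log units; beyond the scatter) lies beyond the scatter, so the gap to the chain of compound 1 also holds for this third group on the oxygen. Nothing available explains these results. The compounds shown leave open whether an amine or a carboxylic acid on the phenyl ring would move the number, and what a longer chain on the carbonyl carbon in place of (3-chlorophenoxy)methyl would give.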